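Bombesin receptor subtype-3 agonists: compound 4 from compound 2

The source may hold more compounds than are shown below. What is called first, only, known or untested is meant among the compounds shown, and "the series" means these compounds.

Series notes. The shared core carries the same biaryl acid and imidazole throughout; compound 1 `CCCCc1cnc(C(CCCO)Cc2ccc(-c3ccccc3C(=O)O)cc2)[nH]1` gives 238 nM in an in vitro functional assay on cells for agonist activity at Bombesin receptor subtype-3 (Mus musculus), read by luminescence and calcium flux; a higher number here means that more compound is needed for the effect, a lower number that less compound is needed. Compound 2 `CC(C)(C)c1cnc(CCc2ccc(-c3ccccc3C(=O)O)cc2)[nH]1` gives 2750 nM and compound 3 `CCCCc1cnc(C(Cc2ccc(-c3ccccc3C(=O)O)cc2)C(C)C)[nH]1` gives 2240 nM; these two sit within the scatter of each other, and both sit well apart from compound 1. Among the compounds with values here, the one measured step, a 9.4-fold higher number from compound 1 to compound 3 (0.97 log units; beyond the scatter), concerns the chain carbon and not the aromatic carbon. Compound 4 `O=C(O)c1ccccc1-c1ccc(CCc2ncc(CC3CC3)[nH]2)cc1` differs from compound 2 by cyclopropylmethyl in place of tert-butyl on an aromatic carbon. Within the data shown here, no measured step touches that position, so no movement beyond the scatter is expected, and the estimated step is a 1.3-fold lower number from compound 2 to compound 4 (0.10 log units; within the scatter). Compound 4 is therefore expected at about 2200 nM, in the range 700 nM to 7000 nM.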

Compound 4, half-maximal effective concentration: 72 nM
Compound 4: the middle estimate sits 31-fold (1.49 log units) above what was measured, and the stated range ends above it.
By their numbers in this assay, from the lowest: compound 4; then compound 1; then compounds 3 and 2 (each within the scatter of the next).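

The aromatic carbon on the five-membered ring proves sensitive to the shape of its substituent. In this assay, cyclopropylmethyl in place of tert-butyl gives a 38-fold lower number from compound 2 to compound 4 (1.58 log units; beyond the scatter), although the two groups have the same heavy-atom count and neither has a hydrogen-bond donor or acceptor. The evidence at hand offers no explanation for a step of this size.

On these data alone, it remains open whether the gain depends on the three-membered ring itself; an isobutyl or cyclobutyl group at this carbon would test that. As far as these compounds go, it is also open whether the step carries over to compounds with a substituted chain carbon.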